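Swapping Chloro for Hydroxy on a Cytotoxic Core

This account rests on a few compounds, and the source may have more. Where it says the series, first, only, none or still open, it means among the compounds named here.

Of the compounds shown here, three sharing one core have been tested in a toxicity assay on Vero cells (Chlorocebus sabaeus) for inhibition, read by MTT assay, with a stated time of 48 h; on this read-out higher numbers stand for weaker inhibition and lower numbers for stronger inhibition. Compound 1 `COc1ccc(/C=C2\N=C3C=CC=CN3C2=O)cc1` and compound 2 `COc1cccc(/C=C2\N=C3C=CC=CN3C2=O)c1` each carry a methoxy group and behave alike: in this assay compound 1 gives 1500 nM, and compound 2 gives 1500 nM. Compound 3 `O=C1/C(=C/c2ccc(Cl)cc2)N=C2C=CC=CN12` carries a chloro group instead; in this assay compound 3 gives 200 nM, the lowest of the three numbers. Among the measured compounds shown here, the only measured step that bears on the coming change is a 7.5-fold lower number from compound 1 to compound 3 (0.88 log units; beyond the scatter).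

Compound 4 `O=C1/C(=C/c2ccc(O)cc2)N=C2C=CC=CN12` has not been measured. It differs from compound 3 by one change: hydroxy in place of chloro on an aromatic carbon. A hydroxy group, like methoxy, places an oxygen on that carbon. Because compound 3 gives 200 nM while methoxy-bearing compound 1 gives 1500 nM, taking the chloro away is expected to move the number back upward, though by how much a single step cannot settle. The expected step is a 5.0-fold higher number from compound 3 to compound 4 (0.70 log units; beyond the scatter). Compound 4 is therefore estimated at 1000 nM in this assay, within a range from 300 nM to 3000 nM.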

Compound 4, half-maximal inhibitory concentration: 1500 nM
Compound 4: the middle estimate sits 1.5-fold (0.18 log units) below what was measured; the measured number falls inside the stated range.
By their numbers in this assay, from the lowest: compound 3; then compounds 1, 2 and 4 (each within the scatter of the next).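

Putting hydroxy in place of chloro at this place, para to a large group, brings a 7.5-fold higher number from compound 3 to compound 4 (0.88 log units; beyond the scatter) in this assay and so removes the lower number seen with chloro. Taking the methyl off the oxygen shows no change at the digits printed from compound 1 to compound 4 (within the scatter) and so leaves the number where it was, which means hydroxy and methoxy cannot be told apart at this place. Of the three groups tested here, chloro alone stands apart from the other two, and both of those put an oxygen on the aromatic carbon.

No measurement is available that explains this difference between chloro and the two oxygen-bearing groups. Going by these compounds, whether fluoro, bromo, an amine or a carboxylic acid at this place would read like chloro or like hydroxy and methoxy remains open.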